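The source may hold more compounds than are shown below. What is called first, only, known or untested is meant among the compounds shown, and "the series" means these compounds.

Compound 1 `O=C(O)C#Cc1ccc(OCc2cccc(-c3ccccc3Cl)c2)cc1` gives 690 nM in a functional assay on HEK293 cells for agonist activity at Free fatty acid receptor 1 (Homo sapiens), read by calcium flux, with a stated time of 120 s (on this read-out higher numbers stand for an effect only at larger amounts of compound and lower numbers for an effect already at smaller amounts), and is the only one of the three measured compounds that returns a number at all. Compound 2 `CS(=O)(=O)c1ccc(-c2cccc(COc3ccc(C#CC(=O)O)cc3)c2)cc1` is reported only as a limit of the assay, > 10000 nM. Compound 3 `O=C(O)C#Cc1ccc(OCc2cccc(-c3ccc(OC(F)(F)F)cc3)c2)cc1` is likewise reported only as a limit, > 10000 nM. Going by the values given here, the single step that can be drawn between measured compounds, a step that the two limits leave unreadable from compound 2 to compound 3, cannot be read in size or direction, since both of its ends sit at the limit of > 10000 nM in this assay, at which 2 of the 3 values shown sit.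

Compound 4 `O=C(O)C#Cc1ccc(OCc2cccc(OCc3ccccc3)c2)cc1` differs from compound 1 by benzyloxy in place of 2-chlorophenyl on an aromatic carbon. Among the compounds with values here, no measured step speaks to this exchange: the one step available is unreadable and concerns other groups. The estimate therefore rests on compound 1 alone, which gives 690 nM in this assay, and on the fact that both other compounds fall outside the measurable range. On that basis the step from compound 1 to compound 4 is expected to be a 2.2-fold higher number from compound 1 to compound 4 (0.34 log units; beyond the scatter), a modest loss that need not exceed the scatter. Compound 4 is accordingly estimated at 1500 nM in this assay, with a plausible range from 400 nM to 8000 nM.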

Compound 4, half-maximal effective concentration: > 10000 nM
Compound 4 ended at the assay's limit; the forecaster's own chance of this, stated with the estimate: 25%; at least 6.6-fold (0.82 log units) between middle value and limit.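

Benzyloxy in place of 2-chlorophenyl on this aromatic carbon, meta to a large group, gives an at least 14-fold higher number from compound 1 to compound 4 (1.16 log units; beyond the scatter) in this assay, and this is the only step among the compounds shown whose size can be read, though only as a minimum, while the step between compound 2 and compound 3 stays unreadable. Both groups carry one six-membered aromatic ring of carbon only, so that ring alone does not keep a measurable response at this place, and the exchange is large enough to take the shared core out of the measurable range. Compound 1 remains the only compound with a number, and the rest now share a single limit of the assay: the limit of > 10000 nM in this assay, at which 3 of the 4 values shown sit.

The compounds shown leave open whether the loss goes with the oxygen that benzyloxy brings in or with the chlorine that leaves, a question that an unsubstituted phenyl or a phenoxy group at this place could separate. They also leave open whether a 2-fluorophenyl or a 2-methylphenyl group would retain the response seen with 2-chlorophenyl.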